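Swapping a triazole arm for a benzamide

The compounds below may be only part of what the source reports. "The series", "measured", "known", "first", "only" and "open" are said of these compounds alone.

Compound 2 `NS(=O)(=O)c1cc(-c2nnc(Cn3cc(-c4ccccc4)nn3)o2)c(Cl)cc1SCc1ccccc1` and compound 1 `CN1CCN(Cc2nnc(-c3cc(S(N)(=O)=O)c(SCc4ccccc4)cc3Cl)o2)CC1` share one core and differ only in the group on a saturated chain carbon bound to an aromatic carbon. In an ADME assay on microsomes from liver (Homo sapiens) for metabolic stability, read by LC-MS, using NADPH, tested at 5 uM (a lower number here means that the compound disappears faster, a higher number that the compound lasts longer), compound 1 gives 0.308 h, and compound 2 gives 0.21 h; the step of a 1.5-fold lower number from compound 1 to compound 2 (0.17 log units; within the scatter) lies within the scatter, so the two compounds are not told apart here, and compound 2 sits among two numbers that read alike. Compound 3 `NS(=O)(=O)c1cc(-c2nnc(CNC(=O)c3ccccc3)o2)c(Cl)cc1SCc1ccccc1` changes the same position once more: benzamido in place of 4-phenyl-1H-1,2,3-triazol-1-yl on a saturated chain carbon bound to an aromatic carbon. Among the measured compounds shown here, the only measured step at this position, a 1.5-fold lower number from compound 1 to compound 2 (0.17 log units; within the scatter), stayed within the scatter, so one swap of an arm there has left the half-life unmoved; no other measured pair bears on this change. A step of a 1.2-fold higher number from compound 2 to compound 3 (0.08 log units; within the scatter) is therefore expected in this assay, with no direction claimed beyond the scatter. Compound 3 is estimated at 0.25 h, with a likely range from 0.1 h to 0.6 h.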

Compound 3, half-life: 0.187 h
Compound 3: the middle estimate sits 1.3-fold (0.13 log units) above what was measured; measured number inside the range.
By their numbers in this assay, from the lowest: compounds 3, 2 and 1 (each within the scatter of the next).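

The saturated chain carbon bound to an aromatic carbon has now carried three different arms, and in this assay none can be told apart from the others. Benzamido in place of 4-phenyl-1H-1,2,3-triazol-1-yl gives a 1.1-fold lower number from compound 2 to compound 3 (0.05 log units; within the scatter), and benzamido in place of 4-methylpiperazin-1-yl gives a 1.6-fold lower number from compound 1 to compound 3 (0.22 log units; within the scatter). So an arm bringing a carbonyl and an amide hydrogen, which neither earlier arm has, still reads alike with both, and the flat result now rests on more than a single swap. No measurement at hand offers a reason for this.

On these data alone, whether a carboxylic acid or a primary amine at this place would move the half-life beyond the scatter stays open. So does the effect of a longer chain carrying the benzamido group.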